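The source may hold more compounds than are shown below. What is called first, only, known or untested is meant among the compounds shown, and "the series" means these compounds.

Three close relatives have already been measured in a functional assay on T47D cells (Homo sapiens) for cytotoxicity, read by sulforhodamine B assay, with a stated time of 48 h; a lower number here means a stronger inhibitor, a higher number a weaker inhibitor. Compound 1 `NS(=O)(=O)c1ccc(N/C=C\C(=O)c2cc3ccccc3oc2=O)cc1` gives 109000 nM, compound 2 `Cc1ccnc(NS(=O)(=O)c2ccc(N/C=C\C(=O)c3cc4ccccc4oc3=O)cc2)n1` gives 24500 nM, and compound 3 `Cc1cc(C)nc(NS(=O)(=O)c2ccc(N/C=C\C(=O)c3cc4ccccc4oc3=O)cc2)n1` gives 62200 nM, which leaves compound 3 second highest of the three numbers, with compound 1 nearest and compound 2 furthest. Compound 4 `Nc1ccc(S(=O)(=O)c2ccc(N/C=C\C(=O)c3cc4ccccc4oc3=O)cc2)cc1` differs from compound 3 by 4-aminophenyl in place of (4,6-dimethylpyrimidin-2-yl)amino on a sulfonyl sulfur. Going by the values given here, no measured step exchanges the sulfonamide nitrogen itself for a ring of carbon; the steps that come closest alter only what sits on that nitrogen: a 4.4-fold lower number from compound 1 to compound 2 (0.65 log units; beyond the scatter), a 1.8-fold lower number from compound 1 to compound 3 (0.24 log units; within the scatter) and a 2.5-fold higher number from compound 2 to compound 3 (0.40 log units; beyond the scatter), all modest or within the scatter. A change at the same place is therefore expected to shift this assay only modestly, with no clear direction. Compound 4 is estimated at 60000 nM, between 20000 nM and 180000 nM, an expected step of a 1.0-fold lower number from compound 3 to compound 4 (0.02 log units; within the scatter).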

Compound 4, half-maximal inhibitory concentration: 91900 nM
The estimate for compound 4 lay 1.5-fold (0.19 log units) below the measured number; the range from low to high includes it.
By their numbers in this assay, from the lowest: compound 2; then compounds 3, 4 and 1 (each within the scatter of the next).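

In this assay, putting 4-aminophenyl on the sulfonyl sulfur removes the sulfonamide nitrogen altogether, yet it gives only a 1.5-fold higher number from compound 3 to compound 4 (0.17 log units; within the scatter) and a 1.2-fold lower number from compound 1 to compound 4 (0.07 log units; within the scatter), so that nitrogen is not required for this weak activity. Only the exchange for (4-methylpyrimidin-2-yl)amino lies beyond the scatter, with a 3.8-fold higher number from compound 2 to compound 4 (0.57 log units; beyond the scatter), and it stays modest. No measured evidence explains these results. Still open, from the compounds shown here alone, is whether the amino group on the new ring matters, as a plain phenyl or a carboxylic acid in its place would test.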